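The compounds below may be only part of what the source reports. "The series", "measured", "known", "first", "only" and "open" are said of these compounds alone.

In an ADME assay on J774.A1 cells (Mus musculus) for cytotoxicity, read by MTT assay, with a stated time of 48 h (a higher number here means that more compound is tolerated, a lower number that less compound is tolerated), compound 1 `COc1cccc(CNC(=O)c2c([N+](=O)[O-])noc2-c2ccc(Cl)cc2Cl)c1` gives 61200 nM. Compound 2 `COc1ccc(CNC(=O)c2c([N+](=O)[O-])noc2-c2ccc(Cl)cc2Cl)cc1OC` carries the change (methoxy in place of hydrogen on an aromatic carbon), and in this assay compound 2 gives 81800 nM; the step is a 1.3-fold higher number from compound 1 to compound 2 (0.13 log units; within the scatter). Compound 3 `COC(=O)c1c(NCc2ccc(OC)cc2)noc1-c1ccc(Cl)cc1Cl` rests on a different core, and the difference between the two cores is not broken down here. In this assay compound 3 gives 34700 nM, within the scatter of compound 1 but beyond the scatter from compound 2. Compound 4 `COC(=O)c1c(NCc2ccc(OC)c(OC)c2)noc1-c1ccc(Cl)cc1Cl` has not yet been measured. It differs from compound 3 by methoxy in place of hydrogen on an aromatic carbon, the same kind of change as that between compound 1 and compound 2, though the place is not identical: there the entering methoxy sits para to a large group, here it sits meta to a large group, in both cases ortho to a methoxy group. In this assay, among the measured compounds shown here, the expected step is a 1.3-fold higher number from compound 3 to compound 4 (0.11 log units; within the scatter), resting on the one earlier step of this kind, a 1.3-fold higher number from compound 1 to compound 2 (0.13 log units; within the scatter). Compound 4 is therefore estimated at 45000 nM, with a range from 20000 nM to 100000 nM.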

Compound 4, half-maximal cytotoxic concentration: 7580 nM
For compound 4 the middle estimate is 5.9-fold (0.77 log units) above the measured one; the measured number lies below the stated range.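

On the core of compound 3, methoxy in place of hydrogen gives a 4.6-fold lower number from compound 3 to compound 4 (0.66 log units; beyond the scatter) in this assay. Set beside the earlier step, the same kind of change did not behave alike on the two cores: the same change on two cores in this assay, a 1.3-fold higher number (0.13 log units; within the scatter) from compound 1 to compound 2 and a 4.6-fold lower number (0.66 log units; beyond the scatter) from compound 3 to compound 4, 6.1-fold (0.79 log units) apart, beyond the scatter of two such steps. This shows that a step read on one core was no safe guide to the other here, but with a single step on each core it does not show how general the gap is, and because the entering methoxy does not sit in quite the same place in the two pairs, the effect of the core cannot be separated from that of the place.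

The compounds shown leave open whether the lower number on the core of compound 3 is tied to methoxy itself or would also follow with another group at that ring carbon, such as a hydroxyl, a fluorine or an amine. They also leave open whether it would persist with a carboxylic acid in place of the methyl ester.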